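This account rests on a few compounds, and the source may have more. Where it says the series, first, only, none or still open, it means among the compounds named here.

Compound 1 `O=C1C[C@H]2O[C@H]([C@H](O)c3ccccc3)[C@H](O)[C@H]2O1`: 8320 nM
Compound 2 `O=C(/C=C/c1ccccc1)O[C@H](c1ccccc1)[C@H]1O[C@@H]2CC(=O)O[C@@H]2[C@H]1O`: 11300 nM

Both were tested in a functional assay on HeLa cells (Homo sapiens) for antiproliferative activity, read by MTT assay, with a stated time of 72 h; on this read-out lower numbers stand for stronger inhibition and higher numbers for weaker inhibition. In this assay compound 2 gives 11300 nM, the higher of the two numbers, while compound 1 gives 8320 nM; the gap between them lies within the scatter, so the two cannot be told apart. Compound 3 `O=C1C[C@H]2O[C@H]([C@H](OC(=O)c3ccccc3)c3ccccc3)[C@H](O)[C@H]2O1` is not yet measured. It differs from compound 2 in one place: phenyl in place of 2-phenylethenyl on a carbonyl carbon. Going by the values given here, no step between measured compounds is known, so nothing indicates a shift beyond the scatter. Compound 3 is therefore expected to give about 9500 nM, between 4000 nM and 22000 nM. The expected step of a 1.2-fold lower number from compound 2 to compound 3 (0.08 log units; within the scatter) should stay within the scatter.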

Compound 3, half-maximal inhibitory concentration: 5690 nM
The estimate for compound 3 lay 1.7-fold (0.22 log units) above the measured number; the measured number falls inside the stated range.
By their numbers in this assay, from the lowest: compounds 3, 1 and 2 (each within the scatter of the next).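

In this assay the swap of 2-phenylethenyl for phenyl on the carbonyl carbon gives a step within the scatter (a 2.0-fold lower number from compound 2 to compound 3 (0.30 log units; within the scatter)), so at this position the double bond outside the aromatic rings can go without a readable shift. Benzoyl in place of hydrogen on an oxygen on a saturated carbon also stays within the scatter (a 1.5-fold lower number from compound 1 to compound 3 (0.17 log units; within the scatter)). No supporting evidence bears on these results. As far as these compounds go, whether an amine or a carboxylic acid on that carbonyl carbon would move the number beyond the scatter remains open.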